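The source may hold more compounds than are shown below. What is called first, only, known or untested is meant among the compounds shown, and "the series" means these compounds.

Measured compounds in an assay for inhibition of Fatty-acid amide hydrolase 1 (Rattus norvegicus); a lower number here means a stronger inhibitor, a higher number a weaker inhibitor:

Compound 1 `NC(=O)c1ccc(-c2cnc(C(O)CCc3ccc(-c4ccccc4)cc3)o2)nc1`, for which compound 1 gives a limit of the assay, > 1000 nM.
Compound 2 `COC(=O)c1ccc(-c2cnc(C(O)CCc3ccc(-c4ccccc4)cc3)o2)nc1`, with compound 2 giving 1100 nM.
Compound 3 `COC(=O)c1cnc(C(=O)CCc2ccc(Oc3ccccc3)cc2)o1`, with compound 3 giving 1.7 nM.

Compound 3 stands lowest of the two numbers; the difference between its core and the core of compound 2 is not broken down here. The change amino in place of methoxy on a carbonyl carbon gives the step that the limit leaves unreadable from compound 2 to compound 1, whose size cannot be read because of the limit of > 1000 nM in this assay, at which 1 of the 3 values shown sits.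

Unmeasured is compound 4 `NC(=O)c1cnc(C(=O)CCc2ccc(Oc3ccccc3)cc2)o1`, which differs from compound 3 by amino in place of methoxy on a carbonyl carbon, the same change as that from compound 2 to compound 1. As that earlier step is unreadable, the expectation for compound 4 rests on compound 3 at 1.7 nM, with a modest step expected, a 2.9-fold higher number from compound 3 to compound 4 (0.47 log units; beyond the scatter). Compound 4 is therefore estimated at 5 nM, expected between 1.5 nM and 20 nM.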

Compound 4, inhibition constant: 6.6 nM
Estimate against measurement, compound 4: 1.3-fold (0.12 log units) below, within the range that was stated.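

In this assay, amino in place of methoxy on a carbonyl carbon gives a 3.9-fold higher number from compound 3 to compound 4 (0.59 log units; beyond the scatter), so on this core the change carries a modest cost and compound 4 still reads 6.6 nM. On the core of compound 2, the same change leads to compound 1, which gives > 1000 nM, a limit of the assay and not a number. The step on that core cannot be read, so these compounds do not show whether the change has a similar size on both cores: the limit of > 1000 nM in this assay, at which 1 of the 4 values shown sits.

The compounds shown leave open how a carboxylic acid or a dimethylamino group would read in place of methoxy on the core of compound 3. They also leave open how either group would read on the core of compound 2.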